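Cyclohexylmethyl in Place of Isopropyl on an Inactive Pair

This account rests on a few compounds, and the source may have more. Where it says the series, first, only, none or still open, it means among the compounds named here.

Two compounds have so far been measured in an assay on isolated protein for inhibition of myosin-2 (Bos taurus), read by spectrophotometry, with a stated time of 24 min; a higher number here means a weaker inhibitor, a lower number a stronger inhibitor:

compound 1 `C/C(=N\C(C)C)c1c(O)c2ccccc2[nH]c1=O` gives >= 100000 nM
compound 2 `C/C(=N\Cc1ccccc1C)c1c(O)c2ccccc2oc1=O` gives >= 100000 nM

The value for compound 1 is a limit of the assay, not a measured number. The value for compound 2 is likewise a limit. Compound 1 therefore stands at the limit of >= 100000 nM in this assay, at which 2 of the 2 values shown sit; nothing in the numbers separates it from compound 2, and neither compound shows measurable inhibition in this assay.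

The unmeasured compound 3 `C/C(=N\CC1CCCCC1)c1c(O)c2ccccc2[nH]c1=O` keeps the core of compound 1 and changes only the group on the imine nitrogen: cyclohexylmethyl in place of isopropyl on a double-bonded nitrogen. For the measured compounds named here, no measured pair shows what such a change does in this assay, so the expectation rests on compound 1 alone. Because compound 1 sits at the limit of >= 100000 nM in this assay, at which 2 of the 2 values shown sit, no step beyond the usual scatter is expected, and the estimated step from compound 1 to compound 3 in this assay is a step that the limit leaves unreadable from compound 1 to compound 3. Compound 3 is thus expected to give about 150000 nM, within a range from 30000 nM to 1000000 nM, and most likely to be reported again only as a limit.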

Compound 3, half-maximal inhibitory concentration: >= 100000 nM
Compound 3 gave a limit, no number; the forecaster's own chance of this, stated with the estimate: 80%; the middle value does not contradict the limit.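

No step from compound 1 to compound 3 can be read in this assay, because both are reported only as limits and not as numbers: the limit of >= 100000 nM in this assay, at which 3 of the 3 values shown sit.

In this assay the compounds shown leave open whether any other group on the double-bonded nitrogen, or any change to the shared core, would give a measured number rather than a limit.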